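A few compounds are considered here, and "the series" means these few. Any claim that something is new, unique, unknown or untested is made for them only; others in the source may bear on it.

Measured in a physicochemical assay for lipophilicity, read by HPLC, using the shake flask method, measured as octanol-water partition, with a stated time of 24 h, at pH 7.4; a higher number here means a more lipophilic compound, a lower number a more polar compound:
compound 1 `COC(=O)Cn1c(=O)oc2c(C(=O)/C=C/c3ccc(O)c(O)c3)cccc21`: 0.86
compound 2 `CC(C)=CCn1c(=O)oc2c(C(=O)/C=C/c3ccc(O)c(F)c3)cccc21`: 1.64
compound 3 `CC(C)=CCn1c(=O)oc2c(C(=O)/C=C/c3cc(F)c(O)c(F)c3)cccc21`: 1.13

Compound 3, at 1.13, stands clearly under compound 2 and within the scatter of compound 1. Compound 4 `CC(C)=CCn1c(=O)oc2c(C(=O)/C=C/c3ccc(O)c(O)c3)cccc21` differs from compound 3 in one group: 3,4-dihydroxyphenyl in place of 3,5-difluoro-4-hydroxyphenyl on a double-bonded chain carbon bound to a double-bonded chain carbon. Going by the values given here, the one measured step that bears on this is a number 0.51 log units lower from compound 2 to compound 3 (beyond the scatter), where fluoro took the place of hydrogen on an aromatic carbon. Among the compounds with values here, compound 1 carries the entering 3,4-dihydroxyphenyl group but differs elsewhere, so it gives no step here. Compound 4 has no fluoro, yet the change is no plain reversal of that step, so a small rise in this assay is expected, one that may stay within the scatter. The expected step is a number 0.27 log units higher from compound 3 to compound 4 (within the scatter). For compound 4 the estimate is 1.4, with an expected range from 0.9 to 1.9.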

Compound 4, distribution coefficient: 0.98
Compound 4: the middle estimate sits 0.42 log units above what was measured; measured number inside the range.
By their numbers in this assay, from the lowest: compounds 1, 4 and 3 (each within the scatter of the next); then compound 2.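

In this assay, 3,4-dihydroxyphenyl in place of 3,5-difluoro-4-hydroxyphenyl on this chain carbon gives a number 0.15 log units lower from compound 3 to compound 4 (within the scatter), so the two groups are not told apart here. Hydroxy in place of fluoro on an aromatic carbon gives a clearer step, a number 0.66 log units lower from compound 2 to compound 4 (beyond the scatter), whereas 2-methylprop-1-en-1-yl in place of methoxycarbonyl gives a number 0.12 log units higher from compound 1 to compound 4 (within the scatter). Nothing available explains these steps. As far as these compounds go, whether a carboxylic acid in place of 3,4-dihydroxyphenyl, or a longer chain in place of 2-methylprop-1-en-1-yl, would shift the number in this assay stays open.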